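One Aryl Ring Changed on a Shared Core

The source may report more compounds than this note shows. Statements on the series, on what has been measured and on what is new or still open speak of the compounds shown alone.

compound 1 `COc1ccccc1/C=C1\CCC/C(=C\c2cccc(OC)c2OC)C1=O` — > 20000 nM
compound 2 `COc1ccc(/C=C2\CCC/C(=C\c3cccc(OC)c3OC)C2=O)c(OC)c1` — > 20000 nM
compound 3 `COc1cccc(/C=C2\CCC/C(=C\c3cc(OC)c(OC)c(OC)c3)C2=O)c1OC` — 5900 nM

In a functional assay on A549 cells (Homo sapiens) for cytotoxicity, read by MTT assay, with a stated time of 72 h (on this read-out lower numbers stand for stronger inhibition and higher numbers for weaker inhibition), compound 1 reaches only the limit of the assay, > 20000 nM, so no number is known for it. Compound 2 likewise gives only the limit > 20000 nM. Among the measured compounds shown here, compound 3 is the one compound with a number, 5900 nM. Compound 1 thus stands at the limit of > 20000 nM in this assay, at which 2 of the 3 values shown sit, and its place among the three is known only as a bound. For the measured compounds named here, the one measured step, a step that the two limits leave unreadable from compound 1 to compound 2, is unreadable as well, so it gives no size to lean on.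

Compound 4 `COc1cc(/C=C2\CCC/C(=C\c3cccc(OC)c3OC)C2=O)ccc1O` differs from compound 1 by 4-hydroxy-3-methoxyphenyl in place of 2-methoxyphenyl on a double-bonded chain carbon bound to a double-bonded ring carbon. Going by the values given here, no measured step covers this change. All the values show is that compound 3, which also carries a differently substituted ring on the shared core, gives a number where compound 1 gives a limit, which suggests the core can reach measurable inhibition once the ring changes.

Compound 4 is expected to give in this assay a value near 8000 nM, within 2500 nM to 30000 nM. That would be an estimated step of an at least 2.5-fold lower number from compound 1 to compound 4 (0.39 log units; beyond the scatter), with a real chance that only a limit is reported again.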

Compound 4, half-maximal inhibitory concentration: > 20000 nM
Compound 4 was reported as a limit; the forecaster's own chance of this, stated with the estimate: 35%; middle value at least 2.5-fold (0.39 log units) from the limit.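

Among the compounds shown here, compound 4 gives only a limit, as compound 1 does, so no step from compound 1 to compound 4 can be read, and both stand at one bound: the limit of > 20000 nM in this assay, at which 3 of the 4 values shown sit. The compounds shown leave open whether 4-hydroxy-3-methoxyphenyl in place of 2-methoxyphenyl changes the read-out at all on the shared core, and by how much.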